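A few compounds are considered here, and "the series" means these few. Any claim that something is new, unique, unknown or untested is made for them only; others in the source may bear on it.

Working notes on the series. The shared core carries a sulfonamide whose nitrogen bears an aryl group, and the three measured compounds differ only on that aryl. In a functional assay on HT-29 cells (Homo sapiens) for antiproliferative activity, read by sulforhodamine B assay, with a stated time of 48 h (a lower number here means a stronger inhibitor, a higher number a weaker inhibitor), compound 1 `O=C1NCCN1c1ccc(S(=O)(=O)Nc2ccc(F)cc2)cc1` gives 370 nM. Compound 2 `CCCCc1ccc(NS(=O)(=O)c2ccc(N3CCNC3=O)cc2)cc1` gives 610 nM in this assay, and compound 3 `CCCCOc1ccc(NS(=O)(=O)c2ccc(N3CCNC3=O)cc2)cc1` gives 630 nM. Compound 1 has the lowest of the three numbers, yet both steps away from it, a 1.6-fold higher number from compound 1 to compound 2 (0.22 log units; within the scatter) and a 1.7-fold higher number from compound 1 to compound 3 (0.23 log units; within the scatter), stay within the scatter, as does a 1.0-fold higher number from compound 2 to compound 3 (0.01 log units; within the scatter). So far the aryl group on the sulfonamide nitrogen has tolerated each change without a number beyond the scatter.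

Compound 4 `Cc1ccccc1NS(=O)(=O)c1ccc(N2CCNC2=O)cc1` is the next member. Its difference from compound 1 is 2-methylphenyl in place of 4-fluorophenyl on a sulfonamide nitrogen. Going by the values given here, no measured step makes this change: the three steps known replace fluoro with butyl or butoxy on an aromatic carbon, whereas here the whole aryl is exchanged for 2-methylphenyl. They bear on it only in showing that changes on this aryl have so far moved this assay by no more than the scatter. On that basis no step beyond the scatter is expected, and the estimated step of a 1.4-fold higher number from compound 1 to compound 4 (0.13 log units; within the scatter) is taken to be small in either direction. Compound 4 is therefore expected to give about 500 nM in this assay, with a range from 200 nM to 1300 nM.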

Compound 4, half-maximal inhibitory concentration: 200 nM
Beside the measured number, compound 4's estimate is 2.5-fold (0.40 log units) above it; measured number inside the range.
By their numbers in this assay, from the lowest: compounds 4, 1, 2 and 3 (each within the scatter of the next, the first and the last beyond it).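

Exchanging the whole aryl on the sulfonamide nitrogen, with 2-methylphenyl in place of 4-fluorophenyl, gives a 1.9-fold lower number from compound 1 to compound 4 (0.27 log units; within the scatter), so this position accepts more than the replacement of fluoro by butyl or butoxy, at least with the heavy-atom count unchanged. The series now also has its first pair beyond the scatter: in this assay compound 4 gives 200 nM and compound 3 gives 630 nM, while every neighbouring pair in the order of the numbers stays within the scatter, so the spread shows only between the two ends. Nothing shown gives a measured reason for either observation.

With fluoro lost and methyl gained in a single step, the compounds shown cannot separate the contribution of the two groups, and a plain phenyl or a 4-methylphenyl on the sulfonamide nitrogen would be needed to tell them apart. Going by these compounds, it also remains open how this position responds to a group of a different kind, such as an amine or a carboxylic acid on the aryl, since only fluoro, methyl, butyl and butoxy appear here.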